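Ethoxy in place of 3,5-dimethyl-1H-pyrazol-1-yl: an expected step

The source may hold more compounds than are shown below. What is called first, only, known or untested is meant among the compounds shown, and "the series" means these compounds.

Of the compounds shown here, three sharing one core have been measured in an assay on HEK293 cells for displacement of a labelled ligand from growth hormone secretagogue receptor type 1 (Homo sapiens), with a stated time of 60 min; on this read-out lower numbers stand for stronger inhibition and higher numbers for weaker inhibition. Compound 1 `Cc1ccnn1-c1ccc(Cl)c(C(=O)NC(=O)Nc2nc3ccc(S(=O)(=O)C4CCN(C)CC4)cc3s2)c1` gives 33 nM, compound 2 `CN1CCC(S(=O)(=O)c2ccc3nc(NC(=O)NC(=O)c4cc(N5CCCC5)c(C#N)cc4Cl)sc3c2)CC1` gives 0.4 nM, and compound 3 `Cc1cc(C)n(-c2ccc(Cl)c(C(=O)NC(=O)Nc3nc4ccc(S(=O)(=O)CCCN5CCN(C)CC5)cc4s3)c2)n1` gives 1.3 nM. Compound 3 thus stands second highest of the three numbers: compound 2 sits at a lower number, beyond the scatter, while compound 1 sits at a much higher one, also beyond the scatter. Compound 4 `CCOc1ccc(Cl)c(C(=O)NC(=O)Nc2nc3ccc(S(=O)(=O)CCCN4CCN(C)CC4)cc3s2)c1` differs from compound 3 in one place: ethoxy in place of 3,5-dimethyl-1H-pyrazol-1-yl on an aromatic carbon. Among the compounds with values here, no pair of measured compounds isolates this change, so no measured step can be drawn on. A modest rise in this assay is expected, the step of a 3.1-fold higher number from compound 3 to compound 4 (0.49 log units; beyond the scatter) lying a little beyond the scatter. Compound 4 is estimated at 4 nM, within a range from 1 nM to 15 nM.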

Compound 4, half-maximal inhibitory concentration: 0.31 nM
The estimate for compound 4 lay 13-fold (1.11 log units) above the measured number, outside the stated range (below it).
By their numbers in this assay, from the lowest: compounds 4 and 2 (each within the scatter of the next); then compound 3; then compound 1.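

In this assay, putting ethoxy in place of 3,5-dimethyl-1H-pyrazol-1-yl on this aromatic carbon, para to a chloro group, gives a 4.2-fold lower number from compound 3 to compound 4 (0.62 log units; beyond the scatter). The five-membered aromatic ring is therefore not required here for a low number, and a smaller group with no ring does better, beyond the scatter. Nothing available accounts for this gain. On these data alone, it remains open whether the oxygen or the length of the chain matters, which methoxy, propoxy or an amine at this carbon would help to separate. As far as these compounds go, whether ethoxy behaves likewise on the core of compound 1 is also open.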